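Swapping Methyl for Phenyl: Expecting the Value of Compound 4

This account rests on a few compounds, and the source may have more. Where it says the series, first, only, none or still open, it means among the compounds named here.

Three compounds have so far been measured in a functional assay on NCI-H2122 cells (Homo sapiens) for inhibition, read by microscopy, with a stated time of 10 days; on this read-out higher numbers stand for weaker inhibition and lower numbers for stronger inhibition:

Compound 1, `Cc1nn(C)c2c1C(c1cc(F)cc(F)c1)C(C#N)=C(N)O2`, gives 4200 nM.
Compound 2, `Cn1nc(-c2ccccc2)c2c1OC(N)=C(C#N)C2c1cc(F)cc(F)c1`, gives 6600 nM.
Compound 3, `Cc1nn(C)c2c1C(c1ccc3c(c1)OCCO3)C(C#N)=C(N)O2`, gives 8600 nM.

Compound 1 and compound 2 share a core and differ in one place: phenyl in place of methyl on an aromatic carbon. That change produced a 1.6-fold higher number from compound 1 to compound 2 (0.20 log units; within the scatter), so the two numbers cannot be told apart with confidence. Compound 3 carries the same methyl group as compound 1 but a different group on the other ring; the difference between these two cores is not broken down here. Compound 3 has the highest number of the three, though its gap to compound 2 falls within the scatter and only its gap to compound 1 lies beyond it.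

Compound 4, `Cn1nc(-c2ccccc2)c2c1OC(N)=C(C#N)C2c1ccc2c(c1)OCCO2`, has not yet been measured. It differs from compound 3 in one place: phenyl in place of methyl on an aromatic carbon. The surroundings of that place are the same in both pairs, so this is the same change made on a second core. Going by the values given here, only one earlier example of it exists, and it came from a single pair, so the expectation rests on that pair alone: compound 2 moved by a 1.6-fold higher number from compound 1 to compound 2 (0.20 log units; within the scatter) away from compound 1, and compound 3 starts at 8600 nM. For compound 4 the expected step is a 1.5-fold higher number from compound 3 to compound 4 (0.18 log units; within the scatter). Compound 4 is therefore estimated at 13000 nM, with a likely range from 5000 nM to 35000 nM.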

Compound 4, half-maximal inhibitory concentration: 8400 nM
The estimate for compound 4 lay 1.5-fold (0.19 log units) above the measured number, within the range that was stated.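

In this assay, putting phenyl in place of methyl on the aromatic carbon of the second core gives a 1.0-fold lower number from compound 3 to compound 4 (0.01 log units; within the scatter), so the two numbers of this pair cannot be told apart with confidence. Set side by side, the two examples of this change do not differ by more than repeated measurements of this kind would be expected to: the same change on two cores in this assay, a 1.6-fold higher number (0.20 log units; within the scatter) from compound 1 to compound 2 and a 1.0-fold lower number (0.01 log units; within the scatter) from compound 3 to compound 4, 1.6-fold (0.21 log units) apart, within the scatter of two such steps. Going by these compounds alone, this shows that on these two cores, replacing methyl (1 heavy atom) with phenyl (6 heavy atoms) produces no step that can be read in this assay, and that the outcome on one core agrees with the outcome on the other; it does not show that the change has no effect at all, since a small real step could lie hidden in the scatter, and two pairs cannot speak for other cores.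

The compounds shown leave open what other groups on that same carbon would do, for example an amine, a carboxylic acid or a longer chain. They also leave open whether a phenyl ring bearing a fluorine or a methoxy group would move the number beyond the scatter.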